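A few compounds are considered here, and "the series" means these few. Any claim that something is new, unique, unknown or untested is made for them only; others in the source may bear on it.

Of the compounds shown here, three have so far been measured in a functional assay on HEK293 cells for agonist activity at D(4) dopamine receptor (Homo sapiens), read by FLIPR; on this read-out lower numbers stand for smaller maximal responses and higher numbers for larger maximal responses. Compound 2 `Cc1cc(NC(=O)CN2CCC(c3cccc[n+]3[O-])CC2)ccc1F` gives 75% in this assay, the highest of the three numbers. Going by the values given here, compound 1 `Cc1ccc(C(=O)NCN2CCC(c3cccc[n+]3[O-])CC2)cc1C` gives 65% in this assay, a number that lies within the usual scatter of the one for compound 2, so the two cannot be told apart. Compound 3 `Cc1cccc(NC(=O)CN2CCC(c3ccccc3F)CC2)c1` gives 57% in this assay, and this number does lie beyond the scatter below compound 2. Compounds 1 and 3 each differ from compound 2 in more than one place, so no single change can be read from these pairs.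

Compound 4 `Cc1cccc(C)c1NC(=O)CN1CCC(c2cccc[n+]2[O-])CC1` has not yet been measured. It differs from compound 2 in one place: 2,6-dimethylphenyl in place of 4-fluoro-3-methylphenyl on an amide-type nitrogen. Among the compounds with values here, no measured pair shows this change on its own, so there is no step to lean on. The group that leaves and the group that enters have the same count of heavy atoms and neither carries a hydrogen-bond donor or acceptor, which gives no ground to expect a large shift. A small downward step is expected here, a number 9 percentage points lower from compound 2 to compound 4 (within the scatter), possibly inside the scatter. Compound 4 is therefore estimated to give 66% in this assay, with a range from 46% to 84%.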

Compound 4, largest response reached (reported as efficacy), in percent of the reference or control that the assay uses: 68%
For compound 4 the middle estimate is 2 percentage points below the measured one; low and high end bracket the measured number.
By their numbers in this assay, from the lowest: compounds 3, 1, 4 and 2 (each within the scatter of the next, the first and the last beyond it).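

Going by these compounds alone, the pair of compounds differing only in this group gives the first single-change step: in this assay there is a number 7 percentage points lower from compound 2 to compound 4 (within the scatter), so the two groups cannot be told apart on this read-out. Within the data shown here, with the rest of the molecule held the same, a phenyl ring carrying a fluorine and a methyl and a phenyl ring carrying two methyls, both with the same count of heavy atoms, give maximal responses that are not separated when placed on the amide-type nitrogen, something the earlier compounds could not show since each of them differs from the others in more than one place. Nothing measured here speaks to why these two groups give such similar numbers.

Still open, on these data alone, is whether a group of another kind on this nitrogen, such as a cyclohexyl group or a phenyl ring carrying a carboxylic acid, would shift the maximal response beyond the scatter. Also open, as far as these compounds go, is whether the same exchange of groups would give a similar step on the core of compound 3, which has no measured partner of this kind.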